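The source may hold more compounds than are shown below. What is called first, only, known or untested is meant among the compounds shown, and "the series" means these compounds.

Measured compounds:
compound 1, `OC[C@H]1O[C@@H](n2cnc3c(NCc4cccc(F)c4)ncnc32)[C@H](O)[C@@H]1O`, gives 15300 nM
compound 2, `OC[C@H]1O[C@@H](n2cnc3c(NCc4cccc(Br)c4)ncnc32)[C@H](O)[C@@H]1O`, gives > 166000 nM (a limit)
compound 3, `COc1cccc(CNc2ncnc3c2ncn3[C@@H]2O[C@H](CO)[C@@H](O)[C@H]2O)c1`, gives > 166000 nM (a limit)

In a functional assay on MCF cells (Homo sapiens) for antiproliferative activity, with a stated time of 72 h (on this read-out lower numbers stand for stronger inhibition and higher numbers for weaker inhibition), compound 1 gives 15300 nM. Compound 2 reaches only a limit of this assay, > 166000 nM. Compound 3 likewise reaches only a limit, > 166000 nM. Compound 3 therefore stands at the weak end of the numbers shown, at the limit of > 166000 nM in this assay, at which 2 of the 3 values shown sit. The two readable steps are an at least 10-fold higher number from compound 1 to compound 2 (1.03 log units; beyond the scatter) and an at least 10-fold higher number from compound 1 to compound 3 (1.03 log units; beyond the scatter); the third, a step that the two limits leave unreadable from compound 2 to compound 3. Compound 4, `COc1cc(CNc2ncnc3c2ncn3[C@@H]2O[C@H](CO)[C@@H](O)[C@H]2O)cc(OC)c1`, differs from compound 3 by methoxy in place of hydrogen on an aromatic carbon. Among the compounds with values here, no measured step swaps methoxy for hydrogen, so this change has no direct precedent; what the measured steps do show is that replacing the fluoro on that ring carried compound 1 to the limit twice. With compound 3 already at the limit, compound 4 is expected to remain there, and the step that the limit leaves unreadable from compound 3 to compound 4 is expected to be unreadable rather than a gain. The estimate for compound 4 is 250000 nM, ranging from 60000 nM to 800000 nM.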

Compound 4, half-maximal inhibitory concentration: > 166000 nM
Compound 4: only a limit was reported; the forecaster's own chance of this, stated with the estimate: 80%; the middle value is on the limit's open side.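

In this assay compound 4 also reaches only a limit, > 166000 nM. Within the data shown here, a second methoxy on the ring, giving 3,5-dimethoxyphenyl, therefore brings back no readable activity; the steps among the compounds held at the limit cannot be read, so its effect on compound 3 stays unknown, and the one readable new step is an at least 10-fold higher number from compound 1 to compound 4 (1.03 log units; beyond the scatter). Of the four rings now shown, only the 3-fluorophenyl of compound 1 gives a number rather than a limit, and the others sit together: the limit of > 166000 nM in this assay, at which 3 of the 4 values shown sit.

The compounds shown leave open how far beyond the limit compounds 2, 3 and 4 lie. They also leave open whether a chloro or a nitrile in place of the fluoro would keep a number like that of compound 1, 15300 nM.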